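Thiophene to thiazole on the amine-bound methylene

The source may hold more compounds than are shown below. What is called first, only, known or untested is meant among the compounds shown, and "the series" means these compounds.

Among the measured compounds shown here, compound 3 `Cc1csc(CN[C@@H]2C[C@H]3C[C@@H]([C@H]2C)C3(C)C)c1` holds the only plain number in an ADME assay on MDCK cells (Canis lupus familiaris) for cytotoxicity, read by microscopy, with a stated time of 48 h (a lower number here means that less compound is tolerated, a higher number that more compound is tolerated), giving 12500 nM. Compound 1 `C[C@H]1[C@H](NCc2cncnc2)C[C@H]2C[C@@H]1C2(C)C` returns only a limit, > 100000 nM. Compound 2 `Cc1n[nH]cc1CN[C@@H]1C[C@H]2C[C@@H]([C@H]1C)C2(C)C` likewise returns only a limit, > 100000 nM. Compound 4 `Cc1csc(CN[C@@H]2C[C@H]3C[C@@H]([C@H]2C)C3(C)C)n1` is not yet measured; it differs from compound 3 by 4-methyl-1,3-thiazol-2-yl in place of 4-methylthiophen-2-yl on a saturated chain carbon bound to an amine nitrogen. The steps bearing on it are an at least 8.0-fold lower number from compound 1 to compound 3 (0.90 log units; beyond the scatter) and an at least 8.0-fold lower number from compound 2 to compound 3 (0.90 log units; beyond the scatter), both reaching compound 3 from the limit of > 100000 nM in this assay, at which 2 of the 3 values shown sit, so each is known only as a lower bound. Both leave compound 3 at the lowest number while the heteroaryls carrying ring nitrogen sit at the limit; the entering 4-methyl-1,3-thiazol-2-yl also carries ring nitrogen, so a rise in this assay is expected, smaller than those steps, a 3.2-fold higher number from compound 3 to compound 4 (0.51 log units; beyond the scatter). Compound 4 is estimated at 40000 nM, within 12500 nM to 100000 nM.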

Compound 4, minimum cytotoxic concentration: > 100000 nM
Compound 4 was reported as a limit; the forecaster's own chance of this, stated with the estimate: 40%; middle value at least 2.5-fold (0.39 log units) from the limit.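

The change of 4-methylthiophen-2-yl to 4-methyl-1,3-thiazol-2-yl on a saturated chain carbon bound to an amine nitrogen keeps the sulfur and adds a ring nitrogen, and in this assay it gives an at least 8.0-fold higher number from compound 3 to compound 4 (0.90 log units; beyond the scatter). Among these four compounds, every heteroaryl with ring nitrogen now sits at the limit, and no compound goes against this. The steps among compound 1, compound 2 and compound 4 cannot be read, because all three stand at one limit: the limit of > 100000 nM in this assay, at which 3 of the 4 values shown sit.

Going by these compounds, how far compound 4 lies past that limit stays open, so the step is only a lower bound. Also open, on these data alone, is whether a phenyl ring or a pyridine ring at this place would follow compound 3 or compound 4.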